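Bromo to methyl: a repeated swap on two related cores

The source may report more compounds than this note shows. Statements on the series, on what has been measured and on what is new or still open speak of the compounds shown alone.

Compound 1 `Fc1ccc(CNc2nc(Nc3cc(C4CC4)[nH]n3)c3cc(Br)ccc3n2)c(F)c1` and compound 2 `Cc1ccc2nc(NCc3ccc(F)cc3F)nc(Nc3cc(C4CC4)[nH]n3)c2c1` share a core and differ in one place, (methyl in place of bromo on an aromatic carbon). In an assay for inhibition of high affinity nerve growth factor receptor (Homo sapiens), read by HTRF, with a stated time of 30 min, in the presence of a further agent that is not named here (on this read-out lower numbers stand for stronger inhibition and higher numbers for weaker inhibition), compound 1 gives 120 nM, while compound 2 gives 57 nM, so the change made a 2.1-fold lower number from compound 1 to compound 2 (0.32 log units; beyond the scatter). Compound 3 `Cc1cc(Nc2nc(NCc3ccc(F)cc3F)nc3cc(Br)ccc23)n[nH]1` has a different core; the difference between the two cores is not broken down here. In this assay compound 3 gives 53 nM, close to compound 2. Compound 4 `Cc1ccc2c(Nc3cc(C)[nH]n3)nc(NCc3ccc(F)cc3F)nc2c1` is not yet measured and differs from compound 3 by the same change, (methyl in place of bromo on an aromatic carbon). Because compound 1 to compound 2 made a 2.1-fold lower number from compound 1 to compound 2 (0.32 log units; beyond the scatter), a step of similar size, a 2.0-fold lower number from compound 3 to compound 4 (0.31 log units; beyond the scatter), is expected from compound 3 to compound 4. Compound 4 is therefore estimated at 26 nM in this assay, with a likely range from 12 nM to 55 nM.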

Compound 4, half-maximal inhibitory concentration: 27 nM
Compound 4: the middle estimate sits 1.0-fold (0.02 log units) below what was measured, and the stated range covers the measured number.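

Replacing bromo with methyl on the core of compound 3 gave, in this assay, a 2.0-fold lower number from compound 3 to compound 4 (0.29 log units; within the scatter). Set beside the earlier swap, the two steps agree in size: the same change on two cores in this assay, a 2.1-fold lower number (0.32 log units; beyond the scatter) from compound 1 to compound 2 and a 2.0-fold lower number (0.29 log units; within the scatter) from compound 3 to compound 4, 1.1-fold (0.03 log units) apart, within the scatter of two such steps. For the compounds shown here, the change therefore carried over from one core to the other in these two pairs, but that is only two examples in one assay, the newer step on its own lies within the scatter, and neither pair explains why the swap acts as it does or shows that it would hold on further cores.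

The compounds shown leave open what other groups on this aromatic carbon, such as an amine, a chloro group or a carboxylic acid, would do. They also leave open whether the two steps would match on any other read-out.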